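Replacing an Isopropylamide with a Hydroxyazetidine Amide

A few compounds are considered here, and "the series" means these few. Any claim that something is new, unique, unknown or untested is made for them only; others in the source may bear on it.

Measured so far:
compound 1, `CNC(=O)c1c(-c2ccccc2)c([C@H](C)Nc2ncnc(N)c2C#N)nc2ccc(F)cc12`, 1240 nM
compound 2, `CCNC(=O)c1c(-c2ccccc2)c([C@H](C)Nc2ncnc(N)c2C#N)nc2ccc(F)cc12`, 17000 nM
compound 3, `CC(C)NC(=O)c1c(-c2ccccc2)c([C@H](C)Nc2ncnc(N)c2C#N)nc2ccc(F)cc12`, 8050 nM

In an assay on Sf9 cells for inhibition of phosphatidylinositol 4,5-bisphosphate 3-kinase catalytic subunit beta isoform (Homo sapiens), with a stated time of 20 min (a higher number here means a weaker inhibitor, a lower number a stronger inhibitor), compound 3 stands second highest of the three numbers, with a 6.5-fold higher number from compound 1 to compound 3 (0.81 log units; beyond the scatter) and a 2.1-fold lower number from compound 2 to compound 3 (0.32 log units; beyond the scatter). Compound 4, `C[C@H](Nc1ncnc(N)c1C#N)c1nc2ccc(F)cc2c(C(=O)N2CC(O)C2)c1-c1ccccc1`, differs from compound 3 by 3-hydroxyazetidin-1-yl in place of isopropylamino on a carbonyl carbon. Within the data shown here, no measured step tests a cyclic amine on this carbonyl; the steps among the three amides, a 14-fold higher number from compound 1 to compound 2 (1.14 log units; beyond the scatter) and a 6.5-fold higher number from compound 1 to compound 3 (0.81 log units; beyond the scatter), show only that this position shifts this assay by modest to large amounts. Compound 4 is therefore expected to land near compound 3, with a step of a 2.7-fold lower number from compound 3 to compound 4 (0.43 log units; beyond the scatter), and its value is estimated at 3000 nM, within 500 nM to 20000 nM.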

Compound 4, half-maximal inhibitory concentration: 2720 nM
Estimate against measurement, compound 4: 1.1-fold (0.04 log units) above, and the stated range covers the measured number.
By their numbers in this assay, from the lowest: compound 1; then compound 4; then compound 3; then compound 2.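

In this assay, a cyclic amine is accepted on this carbonyl carbon: 3-hydroxyazetidin-1-yl in place of isopropylamino gives a 3.0-fold lower number from compound 3 to compound 4 (0.47 log units; beyond the scatter), and in place of ethylamino it gives a 6.3-fold lower number from compound 2 to compound 4 (0.80 log units; beyond the scatter). The ring does not match the methylamino group, however, with a 2.2-fold higher number from compound 1 to compound 4 (0.34 log units; beyond the scatter), so compound 1 remains the strongest inhibitor of the four. No evidence at hand accounts for these steps.

On these data alone, what the hydroxyl adds to the ring remains open, and an unsubstituted azetidine amide would separate the two. As far as these compounds go, how a pyrrolidine amide or a 3-aminoazetidine amide would compare at this carbonyl carbon is also open.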